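A small swap at the assay limit

A few compounds are considered here, and "the series" means these few. Any claim that something is new, unique, unknown or untested is made for them only; others in the source may bear on it.

In a functional assay on HT-29 cells (Homo sapiens) for inhibition, read by MTT assay, with a stated time of 72 h (on this read-out higher numbers stand for weaker inhibition and lower numbers for stronger inhibition), compound 1 (`C=C[C@]1(C)C[C@@H](OC(=O)CNC(=O)Nc2cccc(Br)c2)[C@]2(C)[C@H](C)CC[C@]3(CCC(=O)[C@H]32)[C@@H](C)[C@@H]1O`), with 3-bromophenyl on an amide-type nitrogen, reads > 10000 nM as a limit, not a number. Compound 2 (`C=C[C@]1(C)C[C@@H](OC(=O)CNC(=O)NC(=O)c2cccc(F)c2)[C@]2(C)[C@H](C)CC[C@]3(CCC(=O)[C@H]32)[C@@H](C)[C@@H]1O`) reads > 10000 nM as a limit too. Both sit at the limit of > 10000 nM in this assay, at which 2 of the 2 values shown sit, and neither has a number. For the measured compounds named here, the only measured step is a step that the two limits leave unreadable from compound 1 to compound 2 and it gives no size to carry over. Compound 3 (`C=C[C@]1(C)C[C@@H](OC(=O)CNC(=O)Nc2ccc(F)cc2)[C@]2(C)[C@H](C)CC[C@]3(CCC(=O)[C@H]32)[C@@H](C)[C@@H]1O`) has 4-fluorophenyl in place of (3-fluorophenyl)carbonyl on an amide-type nitrogen. No step beyond the scatter is expected, and the estimated step is a step that the limit leaves unreadable from compound 2 to compound 3 in size. Compound 3 is expected near 15000 nM with an estimated range from 5000 nM to 40000 nM and may well return only a limit again.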

Compound 3, half-maximal inhibitory concentration: > 10000 nM
Compound 3: a limit, no number (the forecaster's own chance of this, stated with the estimate: 85%); the middle value lies beyond the limit too.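

No step can be read between compound 1, compound 2 and compound 3, since all three give a limit rather than a number: the limit of > 10000 nM in this assay, at which 3 of the 3 values shown sit.

The compounds shown leave open whether 3-bromophenyl, (3-fluorophenyl)carbonyl and 4-fluorophenyl differ at all in strength.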